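The source may report more compounds than this note shows. Statements on the series, on what has been measured and on what is new or still open speak of the compounds shown alone.

In an ADME assay for permeability, using PAMPA, at pH 4 (a higher number here means that the compound crosses the layer faster, a lower number that the compound crosses the layer more slowly), two compounds sharing one core have been measured so far. Compound 1 `CCCCC#Cc1c(C)[nH]c2ccc(OC)cc2c1=O` gives 1020 10^-6 cm/s, and compound 2 `CCCCC#Cc1c(C)[nH]c2ccc(Cl)cc2c1=O` gives 171 10^-6 cm/s, the lower of the two numbers. Compound 3 `CCCCC#Cc1c(C)[nH]c2ccc(F)cc2c1=O` differs from compound 2 in one place: fluoro in place of chloro on an aromatic carbon, (fluoro in place of chloro on an aromatic carbon). Within the data shown here, only one measured step bears on this change. It is chloro in place of methoxy at that same carbon, a 6.0-fold lower number from compound 1 to compound 2 (0.78 log units; beyond the scatter), a modest step beyond the scatter. That step shows that a swap at this carbon can move the number in this assay, but fluoro has not yet been measured on this core, and a single step gives no rule for it. A change of direction relative to that step, upward, is the likelier outcome, though it is expected to be smaller than the step to compound 2. The expected step is a 1.8-fold higher number from compound 2 to compound 3 (0.24 log units; within the scatter), and this remains an estimate. For compound 3 the estimated value is 300 10^-6 cm/s, with an expected range from 110 10^-6 cm/s to 800 10^-6 cm/s.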

Compound 3, apparent permeability in the ADME assay: 314 10^-6 cm/s
Compound 3: the middle estimate sits 1.0-fold (0.02 log units) below what was measured; the measured number falls inside the stated range.
By their numbers in the ADME assay, from the lowest: compounds 2 and 3 (each within the scatter of the next); then compound 1.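

In the ADME assay, chloro giving way to fluoro on this aromatic carbon yields a 1.8-fold higher number from compound 2 to compound 3 (0.26 log units; within the scatter), so this exchange does not separate the two halogens in that assay. Fluoro in place of methoxy yields a 3.2-fold lower number from compound 1 to compound 3 (0.51 log units; beyond the scatter), which shows that methoxy stands apart from fluoro as well as from chloro: among these three compounds, the separation at this carbon lies between methoxy and the two halogens. In a physicochemical assay for lipophilicity, at pH 7.4 (a lower number here means a more polar compound, a higher number a more lipophilic compound), compound 2 gives 2.98 and compound 3 gives 5.64. The same exchange of halogens is far from silent in the physicochemical assay, so a large difference in the distribution coefficient between these two compounds came without a step beyond the scatter in the ADME assay: the measured distribution coefficient of compound 2, 2.98, and of compound 3, 5.64, a number 2.66 log units higher (beyond the scatter)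

The compounds shown leave open whether methoxy stands alone at this carbon or whether another oxygen-bearing group, such as ethoxy or hydroxy, or a group of a different kind, such as an amine or a nitrile, would behave as it does. They also leave open whether the same picture would hold if the shared chain were replaced by a shorter chain.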